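The source may report more compounds than this note shows. Statements on the series, on what has been measured and on what is new or still open speak of the compounds shown alone.

Of the compounds shown here, three sharing one core have been measured in an assay on HEK298 cells for displacement of a labelled ligand from D(4) dopamine receptor (Homo sapiens); on this read-out higher numbers stand for weaker inhibition and lower numbers for stronger inhibition. Compound 1 `O=C(N[C@H]1CCN(Cc2ccc(OC(F)(F)F)cc2)C1)c1ccc(-c2cccs2)cc1` gives 78 nM in this assay. Compound 2 `O=C(N[C@H]1CCN(Cc2ccc(OC(F)(F)F)cc2)C1)c1cccc(-c2cccs2)c1` gives 52 nM in this assay. Compound 3 `O=C(N[C@H]1CCN(Cc2cccc(C(F)(F)F)c2)C1)c1ccc(-c2cccs2)cc1` gives 22 nM in this assay, the lowest of the three numbers and therefore the strongest inhibition, since its gap to compound 2 and its gap to compound 1 both lie beyond the usual scatter of repeated measurements. Compound 4 `O=C(N[C@H]1CCN(Cc2ccccc2F)C1)c1ccc(-c2cccs2)cc1` has not yet been measured. Compound 4 differs from compound 3 in a single place: 2-fluorophenyl in place of 3-(trifluoromethyl)phenyl on a saturated chain carbon bound to an amine nitrogen in a ring. Going by the values given here, no pair of measured compounds differs in exactly this way, so the size of this step cannot be read off from the measured data. All three measured numbers sit within a modest span, and a step of moderate size in this assay, more likely towards weaker than towards stronger inhibition, is expected. The step from compound 3 to compound 4 is accordingly estimated as a 2.3-fold higher number from compound 3 to compound 4 (0.36 log units; beyond the scatter). Compound 4 is expected to give 50 nM in this assay, with a likely range from 15 nM to 160 nM.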

Compound 4, inhibition constant: 33 nM
For compound 4 the middle estimate is 1.5-fold (0.18 log units) above the measured one; the range from low to high includes it.
By their numbers in this assay, from the lowest: compounds 3, 4, 2 and 1 (each within the scatter of the next, the first and the last beyond it).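

In this assay, putting 2-fluorophenyl in place of 3-(trifluoromethyl)phenyl on a saturated chain carbon bound to an amine nitrogen in a ring gives a 1.5-fold higher number from compound 3 to compound 4 (0.18 log units; within the scatter). This place therefore accepts a group with 7 heavy atoms and one fluorine as well as one with 10 heavy atoms and three fluorines, without a change that stands out from the scatter. Nothing measured alongside these numbers offers an explanation for this result.

The step alters both the fluorinated group and its numbered position on the phenyl ring, and the compounds shown do not separate these two changes. Also open, going by these compounds, is how the read-out responds when the phenyl ring carries an amine or a carboxylic acid instead of fluorine.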